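This account rests on a few compounds, and the source may have more. Where it says the series, first, only, none or still open, it means among the compounds named here.

In a functional assay on MDA-MB-231 cells (Homo sapiens) for cytotoxicity, read by MTT assay, with a stated time of 72 h (a higher number here means a weaker inhibitor, a lower number a stronger inhibitor), compound 1 `CN(C)CCNc1nc(-c2ccc(NC(=O)Nc3ccccc3F)cc2)nc2ccsc12` gives 600 nM. Within the data shown here, compound 2 `CCN(CC)CCCNc1nc(-c2ccc(NC(=O)Nc3ccccc3F)cc2)nc2ccsc12`, which carries a longer amine-bearing chain, gives 860 nM in this assay, and stands at the higher of the two numbers measured so far; the only neighbour it has is compound 1, and the step of a 1.4-fold higher number from compound 1 to compound 2 (0.16 log units; within the scatter) shows that the two values lie within the usual scatter of each other, so no real separation between them can be claimed.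

Compound 3 `CCN(CC)CCNc1nc(-c2ccc(NC(=O)Nc3ccccc3F)cc2)nc2ccsc12` has not yet been measured. It differs from compound 2 by diethylamino in place of (diethylamino)methyl on a saturated chain carbon, two bonds along the chain from a nitrogen on an aromatic ring, which shortens the chain while keeping the same diethylamine, so that compound 3 shares its chain length with compound 1 and its amine with compound 2. Among the measured compounds shown here, the single step that bears on this change, from compound 1 to compound 2, combined a chain extension with an amine exchange and stayed within the scatter. Since both measured numbers sit close together, the expected step of a 1.2-fold lower number from compound 2 to compound 3 (0.09 log units; within the scatter) is small and without a clear direction. Compound 3 is therefore estimated to give 700 nM in this assay, in a range from 330 nM to 1500 nM.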

Compound 3, half-maximal inhibitory concentration: 580 nM
For compound 3 the middle estimate is 1.2-fold (0.08 log units) above the measured one, and the stated range covers the measured number.
By their numbers in this assay, from the lowest: compounds 3, 1 and 2 (each within the scatter of the next).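

Compound 3 pulls apart the two changes that were joined in the earlier step, since it shares its chain length with compound 1 and its amine with compound 2. In this assay, shortening 3-(diethylamino)propyl to 2-(diethylamino)ethyl with the amine held constant gives a 1.5-fold lower number from compound 2 to compound 3 (0.17 log units; within the scatter), and exchanging dimethylamino for diethylamino with the chain held constant gives a 1.0-fold lower number from compound 1 to compound 3 (0.01 log units; within the scatter). Each change taken alone therefore stays within the scatter, so among these three compounds neither chain length nor the choice between these two amines separates the values, and no information is available on why they stay together.

The compounds shown leave open whether a ring amine such as morpholine or piperidine at the end of the chain, or a chain longer than 3-(diethylamino)propyl, would move the number beyond the scatter. Also open, going by these compounds, is how 3-(dimethylamino)propyl would compare, as it would complete the set of two chains and two amines and show whether the two changes stay this small when combined the other way.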